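The source may hold more compounds than are shown below. What is called first, only, known or untested is meant among the compounds shown, and "the series" means these compounds.

In a functional assay on aorta (strain Wistar) for inhibition, with Thoracic aorta (Rattus norvegicus) as the target (on this read-out lower numbers stand for stronger inhibition and higher numbers for weaker inhibition), compound 1, with the structure `COc1nc(-c2cc3ccccc3o2)cc(-c2ccc(Cl)cc2)c1C#N`, gives 286000 nM. Compound 2, with the structure `CCOc1nc(-c2cc3ccccc3o2)cc(-c2ccc(Cl)cc2)c1C#N`, differs from compound 1 only by the change (methyl in place of hydrogen on a saturated chain carbon bound to an oxygen on an aromatic ring); in this assay compound 2 gives 221000 nM, and the step of a 1.3-fold lower number from compound 1 to compound 2 (0.11 log units; within the scatter) says that this change left the read-out essentially unmoved. Compound 3, with the structure `CCn1cc(-c2cc(-c3cc4ccccc4o3)nc(OC)c2C#N)c2ccccc21`, carries a different core; how its core differs from that of compound 1 is not broken down here. In this assay compound 3 gives 299000 nM, a number that sits within the scatter of the values of both compound 1 and compound 2, so no order among these three can be claimed.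

Compound 4, with the structure `CCOc1nc(-c2cc3ccccc3o2)cc(-c2cn(CC)c3ccccc23)c1C#N`, has not yet been measured. Within the data shown here, it differs from compound 3 by the change (methyl in place of hydrogen on a saturated chain carbon bound to an oxygen on an aromatic ring), which is the same change, at the same kind of place, as the one that turned compound 1 into compound 2. Among the measured compounds shown here, with only one earlier example of this change to lean on, the expectation for compound 4 is that the step of a 1.2-fold lower number from compound 3 to compound 4 (0.10 log units; within the scatter) will be of the same small size, because the step of a 1.3-fold lower number from compound 1 to compound 2 (0.11 log units; within the scatter) stayed within the scatter of this assay. On that basis compound 4 is estimated to give 240000 nM in this assay. For compound 4 the likely range of that estimate runs from 120000 nM to 480000 nM.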

Compound 4, half-maximal inhibitory concentration: 358000 nM
Beside the measured number, compound 4's estimate is 1.5-fold (0.17 log units) below it; measured number inside the range.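

On the second core, the change from methoxy to ethoxy gives a 1.2-fold higher number from compound 3 to compound 4 (0.08 log units; within the scatter) in this assay, so adding this methyl again leaves the read-out essentially unmoved. Set beside the earlier example, this step does not differ from it by more than repeated measurements of this kind would be expected to: the same change on two cores in this assay, a 1.3-fold lower number (0.11 log units; within the scatter) from compound 1 to compound 2 and a 1.2-fold higher number (0.08 log units; within the scatter) from compound 3 to compound 4, 1.5-fold (0.19 log units) apart, within the scatter of two such steps. This shows that, on these two cores, the change from methoxy to ethoxy has no readable effect on the number, which is what carrying it across would predict; it does not show that the change would stay this small on a third core, and two pairs whose steps both lie within the scatter cannot reveal a real direction or a small difference between the cores.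

The compounds shown carry only methoxy or ethoxy on this oxygen, so it remains open whether a longer chain such as propyl or butyl, a branched chain such as isopropyl, or a chain ending in an amine or a carboxylic acid would move the number clearly. On these data alone, it also remains open whether any such group would behave the same way on both cores.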